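The source may report more compounds than this note shows. Statements on the series, on what has been measured and on what is new or still open speak of the compounds shown alone.

Measured compounds:

Compound 1, `N/C(=N\NC(=S)N1CCCCCC1)c1ccccn1`: 6000 nM
Compound 2, `N/C(=N\NC(=S)N1CCOCC1)c1ccccn1`: 7300 nM
Compound 3, `N/C(=N\NC(=S)N1CCOCC1)c1ccc(F)cn1`: 1700 nM

All three compounds were tested in a functional assay on HeLa cells (Homo sapiens) for cytotoxicity, read by MTT assay, with a stated time of 72 h; a lower number here means a stronger inhibitor, a higher number a weaker inhibitor. Compound 1 and compound 2 carry different ring systems on the thiourea end of the molecule; how these two cores differ is not broken down here. In this assay compound 1 gives 6000 nM and compound 2 gives 7300 nM, and these two numbers lie within the usual scatter of each other, so no order between them can be read off.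

Compound 3 differs from compound 2 by one change: fluoro in place of hydrogen on an aromatic carbon. This change produced a 4.3-fold lower number from compound 2 to compound 3 (0.63 log units; beyond the scatter), a step that lies beyond the scatter, with compound 3 giving 1700 nM in this assay.

Compound 4, `N/C(=N\NC(=S)N1CCCCCC1)c1ccc(F)cn1`, has not yet been measured. It differs from compound 1 by the same change: fluoro in place of hydrogen on an aromatic carbon. The surroundings of the new fluoro are the same in both pairs, so the two changes are of the same kind at the same place, on different cores.

Because a 4.3-fold lower number from compound 2 to compound 3 (0.63 log units; beyond the scatter) is the only direct read of this change, the expectation for compound 4 rests on it together with the number for compound 1, 6000 nM. A similar step is expected, namely a 4.0-fold lower number from compound 1 to compound 4 (0.60 log units; beyond the scatter). Compound 4 is therefore estimated at 1500 nM, with a likely range of 600 nM to 4000 nM. Whether a second core carries the change as well as the first is the open question that the measurement will settle.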

Compound 4, half-maximal inhibitory concentration: 900 nM
Compound 4: the middle estimate sits 1.7-fold (0.22 log units) above what was measured, and the stated range covers the measured number.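

Fluoro in place of hydrogen on an aromatic carbon lowers the number again in this assay, this time with a 6.7-fold lower number from compound 1 to compound 4 (0.82 log units; beyond the scatter). Two different cores therefore respond in the same direction, and the sizes of their steps cannot be told apart, so in this small set a step read on one core gave a fair guide to the other: the same change on two cores in this assay, a 4.3-fold lower number (0.63 log units; beyond the scatter) from compound 2 to compound 3 and a 6.7-fold lower number (0.82 log units; beyond the scatter) from compound 1 to compound 4, 1.6-fold (0.19 log units) apart, within the scatter of two such steps. This rests on just two pairs with the fluoro at one place on the ring, so it does not show that the change will carry to every core in the series, and it does not explain why the number falls.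

The compounds shown leave open whether the gain belongs to fluoro in particular or would also appear with another group at the same carbon, such as chloro, methyl, methoxy or an amine. They also leave open whether a fluoro on a different carbon of this ring would give a similar step, and whether a third core, with a different group at the thiourea end, would follow the same pattern.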